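The source may hold more compounds than are shown below. What is called first, only, known or untested is meant among the compounds shown, and "the series" means these compounds.

Compound 3 `CN(C)CCCCCSC1=Nc2ccccc2C(CC(=O)NCc2ccc(F)cc2)N1c1ccccc1` carries a fluoro on the benzyl group of its amide and a plain phenyl on the core. In an assay on cells for inhibition of Voltage-dependent T-type calcium channel subunit alpha-1I (Homo sapiens), read by patch clamp (on this read-out lower numbers stand for stronger inhibition and higher numbers for weaker inhibition), compound 3 gives "not active" (no number reported), so no number stands for it. Compound 4 `CN(C)CCCCCSC1=Nc2ccccc2C(CC(=O)NCc2ccccc2)N1c1ccccc1` differs by hydrogen in place of fluoro on an aromatic carbon, the fluoro giving way to hydrogen so that a 4-fluorobenzyl becomes a benzyl. For the measured compounds named here, the only measured step of the same kind sits on the other aromatic ring: compound 1 `CN(C)CCCCCSC1=Nc2ccccc2C(CC(=O)NCc2ccccc2)N1c1ccc(-c2ccc(F)cc2)cc1` gives 9060 nM, compound 2 `CN(C)CCCCCSC1=Nc2ccccc2C(CC(=O)NCc2ccccc2)N1c1ccc(-c2ccccc2)cc1` gives 1760 nM, and a 5.1-fold lower number from compound 1 to compound 2 (0.71 log units; beyond the scatter). A modest gain of that size is therefore expected, yet from a starting point with no number it can only reach weak inhibition. Compound 4 is estimated at 20000 nM, within 5000 nM to 80000 nM.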

Compound 4, half-maximal inhibitory concentration: 3200 nM
Beside the measured number, compound 4's estimate is 6.3-fold (0.80 log units) above it; the whole stated range lies above it.
By their numbers in this assay, from the lowest: compounds 2 and 4 (each within the scatter of the next); then compound 1.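

On the aromatic ring of the core, hydrogen and phenyl read alike, with a 1.8-fold higher number from compound 2 to compound 4 (0.26 log units; within the scatter) and, against the fluorinated group, a 2.8-fold lower number from compound 1 to compound 4 (0.45 log units; beyond the scatter) at the same place. Going from 4-fluorobenzyl to benzyl turns compound 3, which has no number, into compound 4, which has one, so the size of that step cannot be read, yet fluoro costs inhibition on both rings in the pairs shown. Nothing given here explains these differences. Open, going by these compounds, is whether a chloro or a methyl in place of either fluoro would behave the same way.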